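Dichlorophenyl Sulfones Probed at Metabotropic Glutamate Receptor 5

A few compounds are considered here, and "the series" means these few. Any claim that something is new, unique, unknown or untested is made for them only; others in the source may bear on it.

In an assay on isolated protein for displacement of a labelled ligand from metabotropic glutamate receptor 5 (Homo sapiens), with a stated time of 60 min, tested at 1 uM (on this read-out lower numbers stand for less inhibition and higher numbers for more inhibition at the one concentration tested (going by the name of the read-out)), three compounds have been measured so far:
Compound 1 `Cc1ccc2ncc(S(=O)(=O)c3cc(Cl)cc(Cl)c3)c(N3CCC(C)CC3)c2c1` gives 75%.
Compound 2 `Cc1ccc2ncc(S(=O)(=O)c3ccc(Cl)c(Cl)c3)c(N3CCC(C)CC3)c2c1` gives 82%.
Compound 3 `CC1CCN(c2c(S(=O)(=O)c3cc(Cl)cc(Cl)c3)cnc3c(F)cccc23)CC1` gives 82%.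

Compounds 1 and 2 share a core and differ only by 3,4-dichlorophenyl in place of 3,5-dichlorophenyl on a sulfonyl sulfur; this change made a number 7 percentage points higher from compound 1 to compound 2 (within the scatter). Compound 3 carries a different core, and how the two cores differ is not broken down here. Compound 3 stands level with compound 2 at the digits recorded, and its gap to compound 1 is within the scatter, so no ordering among the three can be read from these numbers.

Compound 4 `CC1CCN(c2c(S(=O)(=O)c3ccc(Cl)c(Cl)c3)cnc3c(F)cccc23)CC1` has not yet been measured. It is related to compound 3 by 3,4-dichlorophenyl in place of 3,5-dichlorophenyl on a sulfonyl sulfur, the same change that separates compound 1 from compound 2, at the same place. Because the earlier step was a number 7 percentage points higher from compound 1 to compound 2 (within the scatter) and compound 3 already gives 82%, compound 4 is expected to move by about a number 4 percentage points higher from compound 3 to compound 4 (within the scatter) in this assay, a step at most comparable to the earlier one and held in by the top of the scale. Compound 4 is therefore estimated at 86%, with a likely range from 72% to 96%.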

Compound 4, a percentage reported as inhibition, at one concentration (the size of the read-out at that concentration, not a potency): 95%
For compound 4 the middle estimate is 9 percentage points below the measured one; low and high end bracket the measured number.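

In this assay, 3,4-dichlorophenyl in place of 3,5-dichlorophenyl on a sulfonyl sulfur gave a number 13 percentage points higher from compound 3 to compound 4 (beyond the scatter). Only this step lies beyond the scatter, but the change raised the printed number on both cores, and the size of the step cannot be said to depend on the core: the same change on two cores in this assay, a number 7 percentage points higher (within the scatter) from compound 1 to compound 2 and a number 13 percentage points higher (beyond the scatter) from compound 3 to compound 4, 6 percentage points apart, within the scatter of two such steps

This supports carrying the change from one of these two cores to the other, but it does not show that the change would behave the same way on any further core, and readings at one concentration give no potency.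

All the compounds shown carry a dichlorophenyl group on the sulfonyl sulfur, so it remains open whether a monochlorophenyl, a trifluoromethylphenyl or a methoxyphenyl group would fit the same picture. Going by these compounds, it also remains open how the change would fare with a morpholine or an open-chain amine in place of the ring amine that all four compounds share.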